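A few compounds are considered here, and "the series" means these few. Any claim that something is new, unique, unknown or untested is made for them only; others in the source may bear on it.

Compound 1, with structure `COc1cc(/C=N/Nc2nc(-c3ccccc3)cs2)c(Br)c(Br)c1OC`, is one of three close relatives tested in an ADME assay on HUVEC cells (Homo sapiens) for inhibition, read by MTT assay, with a stated time of 48 h; on this read-out higher numbers stand for weaker inhibition and lower numbers for stronger inhibition. In this assay compound 1 gives > 100000 nM, which is a limit of the assay rather than a number. Compound 2, `COc1cc(/C=N/Nc2nc(-c3ccccc3)cs2)cc(Br)c1OC`, gives > 100000 nM, also a limit. Compound 3, `COc1cc(/C=N/Nc2nc(-c3cc(C(F)(F)F)cc(C(F)(F)F)c3)cs2)c(Br)c(Br)c1OC`, gives > 100000 nM, again a limit. The change from compound 1 to compound 2, hydrogen in place of bromo on an aromatic carbon, gives a step that the two limits leave unreadable from compound 1 to compound 2. Compound 4, `COc1cc(/C=N/Nc2nc(-c3ccc(F)c(F)c3)cs2)c(Br)c(Br)c1OC`, differs from compound 1 by 3,4-difluorophenyl in place of phenyl on an aromatic carbon. Among the compounds with values here, no measured step covers this exact change. Compound 3, which carries a substituted phenyl in this same place, sits at the limit of > 100000 nM in this assay, at which 3 of the 3 values shown sit. On that basis the expected step is a number no higher from compound 1 to compound 4 (the limit leaves the size open), nothing beyond the scatter. For compound 4 the estimate is 100000 nM, between 40000 nM and 300000 nM, most likely again only a limit.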

Compound 4, half-maximal inhibitory concentration: 54700 nM
Compound 4: middle estimate off by 1.8-fold (0.26 log units), on the high side; measured number inside the range.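

Compound 4 is the only compound shown that gives a real number rather than a limit in this assay, so this place on the five-membered aromatic ring is the first to yield a readable value. As far as these compounds go, putting 3,4-difluorophenyl in place of phenyl gives an at least 1.8-fold lower number from compound 1 to compound 4 (0.26 log units; that floor lies within the scatter), and compound 1 is only a limit, so the true size of the step stays open. The rest of the series gives no number: the limit of > 100000 nM in this assay, at which 3 of the 4 values shown sit.

From the compounds shown here alone, whether an amine or a carboxylic acid on the phenyl at this place would lower the number further remains open. The steps between the compounds at the limit cannot be read, so what the bromo groups contribute is also unknown.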